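The source may report more compounds than this note shows. Statements on the series, on what has been measured and on what is new or still open speak of the compounds shown alone.

Measured so far in a functional assay on U-937 cells (Homo sapiens) for cytotoxicity, read by MTT assay, with a stated time of 48 h; a higher number here means a weaker inhibitor, a lower number a stronger inhibitor:

Compound 1, `CCOc1ccc2nc(Nc3nc4ccc(F)cc4s3)sc2c1`, gives 26600 nM.
Compound 2, `Fc1ccc2nc(Nc3nc4ccc(F)cc4s3)sc2c1`, gives 27400 nM.
Compound 3, `CCOc1ccc2nc(NC(=S)Nc3ccccc3)sc2c1`, gives 37700 nM.

Compounds 1 and 2 share a core; compound 2 carries fluoro in place of ethoxy on an aromatic carbon. This change produced a 1.0-fold higher number from compound 1 to compound 2 (0.01 log units; within the scatter). The values of compound 3 and of compounds 1 and 2 all lie within the usual scatter of one another, so no order among the three is read from them. The difference between the core of compound 3 and the core of compound 1 is not broken down here.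

Compound 4, `Fc1ccc2nc(NC(=S)Nc3ccccc3)sc2c1`, is not yet measured in this assay. It carries fluoro in place of ethoxy on an aromatic carbon; the place is described in the same words as for the change from compound 1 to compound 2, so this is the same change on a different core. The step from compound 3 to compound 4 is expected to be a 1.0-fold higher number from compound 3 to compound 4 (0.00 log units; within the scatter), because the same change gave a 1.0-fold higher number from compound 1 to compound 2 (0.01 log units; within the scatter) on the other core. Compound 4 is therefore estimated at 38000 nM, with the range 19000 nM to 76000 nM.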

Compound 4, half-maximal inhibitory concentration: > 50000 nM
Compound 4: no number, only a limit (the forecaster's own chance of this, stated with the estimate: 10%); middle value at least 1.3-fold (0.11 log units) away from the limit.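

In this assay compound 4 gives > 50000 nM, which is a limit of the assay and not a number. Fluoro in place of ethoxy on an aromatic carbon therefore reads as an at least 1.3-fold higher number from compound 3 to compound 4 (0.12 log units; that floor lies within the scatter), and this gives only a floor for the step on the core of compound 3, not its size. The data neither show that the change carries over from one core to the other with the same result nor show that it does not: the same change on two cores in this assay, a 1.0-fold higher number (0.01 log units; within the scatter) from compound 1 to compound 2 and an at least 1.3-fold higher number (0.12 log units; that floor lies within the scatter) from compound 3 to compound 4; the limit leaves it open whether they differ

Still open, from the compounds shown here alone, is what other groups on that aromatic carbon, such as an amine, a carboxylic acid or a longer chain, would do on either core. Also open, going by these compounds, is whether any such group would bring the core of compound 3 to a value that can be read as a number in this assay.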